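The source may report more compounds than this note shows. Statements on the series, on what has been measured and on what is new or still open speak of the compounds shown alone.

Measured so far in a functional assay on SK-MEL-5 cells (Homo sapiens) for cytotoxicity, read by sulforhodamine B assay, with a stated time of 48 h; on this read-out lower numbers stand for higher toxicity in this test and higher numbers for lower toxicity in this test: compound 1 `ClCc1ccc(Cn2cnc3c(Cl)ncnc32)cc1` gives 74100 nM; compound 2 `Nc1nc(Cl)c2ncn(Cc3ccc(CCl)cc3)c2n1` gives 63100 nM.

Compound 2 holds the lower of these two numbers, with compound 1 nearest; the step of a 1.2-fold lower number from compound 1 to compound 2 (0.07 log units; within the scatter) lies within the scatter, so the two cannot be ranked. Compound 3 `ClCc1ccc(Cn2cnc3c(Cl)nc(Cl)nc32)cc1` differs from compound 2 by chloro in place of amino on an aromatic carbon. Going by the values given here, no measured step covers this change; the only step seen, a 1.2-fold lower number from compound 1 to compound 2 (0.07 log units; within the scatter), altered the same position without leaving the scatter. Compound 3 is therefore expected to stay close to compound 2, at a 1.0-fold higher number from compound 2 to compound 3 (0.01 log units; within the scatter). The estimate for compound 3 is 65000 nM, expected between 25000 nM and 150000 nM.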

Compound 3, concentration lethal to 50% of the cells: 44700 nM
Beside the measured number, compound 3's estimate is 1.5-fold (0.16 log units) above it, within the range that was stated.
By their numbers in this assay, from the lowest: compounds 3, 2 and 1 (each within the scatter of the next).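

In this assay three groups have now been compared on the aromatic carbon between two ring nitrogen atoms: hydrogen, amino and chloro. Chloro in place of amino gives a 1.4-fold lower number from compound 2 to compound 3 (0.15 log units; within the scatter) and chloro in place of hydrogen gives a 1.7-fold lower number from compound 1 to compound 3 (0.22 log units; within the scatter) so these three compounds cannot be ranked, and swapping among these small groups at this position has not moved the number beyond the scatter. Nothing measured here offers an explanation for this result. On these data alone, it remains open whether a methoxy group or a longer chain at this position would move the number beyond the scatter.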